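This account rests on a few compounds, and the source may have more. Where it says the series, first, only, none or still open, it means among the compounds named here.

Measured so far:
Compound 1 `Fc1cccc(Nc2nc(-c3cccc(F)c3)nc3ccc(F)cc23)c1`: 49600 nM
Compound 2 `Nc1cccc(Nc2nc(-c3cccc(F)c3)nc3ccc(F)cc23)c1`: 49700 nM

Both numbers come from a functional assay on U2OS cells (Homo sapiens) for cytotoxicity, read by MTT assay, with a stated time of 48 h; a lower number here means a stronger inhibitor, a higher number a weaker inhibitor. Compound 1 and compound 2 differ only by amino in place of fluoro on an aromatic carbon, and the step of a 1.0-fold higher number from compound 1 to compound 2 (0.00 log units; within the scatter) stays within the scatter, so the two compounds cannot be told apart on these numbers. Among the measured compounds shown here, compound 1 therefore stands on a flat pair, with compound 2 as its only neighbour.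

Compound 3 `Cc1ccc(Nc2nc(-c3cccc(F)c3)nc3ccc(F)cc23)cc1` has not yet been measured. Its difference from compound 1 is 4-methylphenyl in place of 3-fluorophenyl on a nitrogen on an aromatic ring. For the measured compounds named here, no measured step touches the group on this nitrogen; the only step known, from compound 1 to compound 2, sits on an aromatic carbon elsewhere and shows nothing beyond the scatter. What the series shows so far is that a change at one peripheral position left the number where it was, and nothing points to a larger effect from the present change.

Compound 3 is thus expected to give about 50000 nM in this assay, in the range 22000 nM to 110000 nM. The expected step of a 1.0-fold higher number from compound 1 to compound 3 (0.00 log units; within the scatter) is none beyond the scatter.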

Compound 3, half-maximal inhibitory concentration: > 50000 nM
Compound 3: no number, only a limit; the forecaster's own chance of this, stated with the estimate: 20%; the middle value lies on the limit itself.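

In this assay compound 3 gives > 50000 nM, which is a limit of the assay and not a number. The 4-methylphenyl group on the nitrogen in place of the 3-fluorophenyl therefore brings a number no lower from compound 1 to compound 3 (the limit leaves the size open), and in place of the 3-aminophenyl it brings a number no lower from compound 2 to compound 3 (the limit leaves the size open), so this second change to the aryl group on the nitrogen also gives no gain in this assay. The size of both steps to compound 3 cannot be read because the value for compound 3 stands at the end of the readable range: the limit of > 50000 nM in this assay, at which 1 of the 3 values shown sits.

As far as these compounds go, it remains open whether compound 3 is truly weaker than compound 1 and compound 2 or merely lies just past the limit, and the change from 3-fluorophenyl to 4-methylphenyl alters both the group and its place on the ring without separating the two. Also open, from the compounds shown here alone, is whether any group on this ring can bring the number down at all, for example a carboxylic acid or a longer chain ending in an amine in place of the methyl.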